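Enlarging the group on the carbonyl of compound 2

This account rests on a few compounds, and the source may have more. Where it says the series, first, only, none or still open, it means among the compounds named here.

In an ADME assay on Caco-2 cells (Homo sapiens) for permeability, in the apical to basolateral direction, at pH 7.4 (a higher number here means that the compound crosses the layer faster, a lower number that the compound crosses the layer more slowly), compound 1 `Cc1ccc2[nH]c(C(=O)N[C@H]3CN(S(=O)(=O)c4ccccc4)C[C@@H]3C(=O)NC[C@H]3CCCN3C)cc2c1` gives 0.08 10^-6 cm/s while compound 2 `Cc1csc(C(=O)N[C@H]2CN(S(=O)(=O)c3ccccc3)C[C@@H]2C(=O)N[C@H]2CCCNC2)n1` gives 0.18 10^-6 cm/s and compound 3 `Cc1nc(-c2cccc(C(F)(F)F)c2)sc1C(=O)N[C@H]1CN(S(=O)(=O)c2ccccc2)C[C@@H]1C(=O)N[C@H]1CCCNC1` gives 0.46 10^-6 cm/s as its reading. Compound 2 therefore stands in the middle of these three numbers, and both of the others lie beyond the usual scatter from it.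

Compound 4 `O=C(N[C@H]1CN(S(=O)(=O)c2ccccc2)C[C@@H]1C(=O)N[C@H]1CCCNC1)c1cc(-c2ccccc2Cl)on1` has not been measured yet. It keeps the rest of compound 2 but replaces the 4-methyl-1,3-thiazol-2-yl group on a carbonyl carbon with a larger group a group of 12 heavy atoms (9 carbon, 1 nitrogen, 1 oxygen, 1 chlorine; one five-membered aromatic ring with 2 hetero atoms, one six-membered aromatic ring of carbon only) in place of a group of 6 heavy atoms (4 carbon, 1 nitrogen, 1 sulfur; one five-membered aromatic ring with 2 hetero atoms), on a carbonyl carbon that includes a six-membered aromatic ring of carbon only.

Among the compounds with values here, no measured pair shows this change alone, so any forecast is uncertain. Compound 3 also has such a ring in the group on that carbonyl carbon and reads 0.46 10^-6 cm/s in this assay so a rise seems the likelier direction. The expected step is a 2.2-fold higher number from compound 2 to compound 4 (0.35 log units; beyond the scatter) upward, only a little beyond the scatter. For compound 4 the estimated value is 0.4 10^-6 cm/s with an expected range from 0.15 10^-6 cm/s to 1 10^-6 cm/s in this assay overall.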

Compound 4, apparent permeability: 0.31 10^-6 cm/s
Beside the measured number, compound 4's estimate is 1.3-fold (0.11 log units) above it, and the stated range covers the measured number.
By their numbers in this assay, from the lowest: compound 1; then compounds 2, 4 and 3 (each within the scatter of the next, the first and the last beyond it).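

Within the data shown here, this is the first pair that differs only in the group on the carbonyl carbon: the 4-methyl-1,3-thiazol-2-yl group gives way to a group of 12 heavy atoms with an added six-membered aromatic ring of carbon only, and this assay shows a 1.7-fold higher number from compound 2 to compound 4 (0.24 log units; within the scatter). At this position, then, the group can grow from 6 to 12 heavy atoms, with no net charge on either group, without the reading leaving the usual scatter, though this is a single pair. Nothing measured on these compounds accounts for the reading.

From the compounds shown here alone, both groups carry no net charge and the same hydrogen-bond counts, so it remains open how an amine or a carboxylic acid on that carbonyl carbon would read in this assay. The part played by the chlorine in compound 4 also remains open, since no compound shown has the same group without that atom.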